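From a halogenated phenyl to a methylphenyl

A few compounds are considered here, and "the series" means these few. Any claim that something is new, unique, unknown or untested is made for them only; others in the source may bear on it.

Of the compounds shown here, three built on a shared core have been tested in a functional assay on HeLa cells (Homo sapiens) for cytotoxicity, read by CCK-8 assay, with a stated time of 72 h; on this read-out higher numbers stand for weaker inhibition and lower numbers for stronger inhibition. Compound 1 `COc1ccccc1/C=c1\c(=O)[nH]/c(=C/c2cccc(Cl)c2Cl)c(=O)n1C` gives 200 nM. Compound 2 `C=CCn1c(=O)/c(=C\c2ccc(F)c(Br)c2)[nH]c(=O)/c1=C\c1ccccc1OC` is reported as "not active" (no number reported), a statement without a number. Compound 3 `C=CCn1c(=O)/c(=C\c2cccc(Br)c2)[nH]c(=O)/c1=C\c1cccc(Br)c1` is likewise reported as "not active" (no number reported), again without a number. Compound 2 therefore stands with no single number of its own, and it is one of two entries in this assay that carry none; only compound 1 has a measured concentration.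

Compound 4 `C=CCn1c(=O)/c(=C\c2ccc(C)cc2)[nH]c(=O)/c1=C\c1ccccc1OC` has not yet been measured. It differs from compound 2 in one place: 4-methylphenyl in place of 3-bromo-4-fluorophenyl on a double-bonded chain carbon bound to an aromatic carbon. Within the data shown here, no measured pair shows how such a change alone shifts the read-out, so the size and direction of the step in this assay are unknown. Among the measured compounds shown here, compound 4 shares the rest of its structure with compound 2, which gave no measurable inhibition, whereas the one numbered compound, compound 1, differs from both in more than this one place. On this basis compound 4 is expected to remain weak, and the likeliest outcome is again a report without a number. If a number does appear, compound 4 is estimated at 20000 nM, with an expected range from 3000 nM to 100000 nM.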

Compound 4, half-maximal inhibitory concentration: "not active" (no number reported)
Nothing numeric was reported for compound 4, and the estimate cannot be compared.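

Compound 2 and compound 4 are both reported as not active in this assay, with no number for either, so no step can be read between them. No measured evidence here explains this result. The compounds shown leave open how much replacing 3-bromo-4-fluorophenyl with 4-methylphenyl changes the read-out on its own.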